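The compounds below may be only part of what the source reports. "The series", "measured", "known", "first", "only" and "open" are said of these compounds alone.

Compound 1: `CC1CC/C(=N\Nc2cccc(Br)c2)c2ncc(C(=O)O)c(=O)n21` — > 320 umol/kg
Compound 2: `CC1CC/C(=N\Nc2ccccc2O)c2ncc(C(=O)O)c(=O)n21` — > 100 umol/kg

In a functional assay on the whole organism for inhibition, with Rattus norvegicus as the target (on this read-out higher numbers stand for an effect only at larger amounts of compound and lower numbers for an effect already at smaller amounts), compound 1 gives > 320 umol/kg, and this is a limit of the assay rather than a number. Compound 2 gives > 100 umol/kg, which is likewise only a limit. So compound 1 stands at a limit, and the one further value shown is a limit as well the limit of > 320 umol/kg in this assay, at which 1 of the 2 values shown sits (the limit of > 100 umol/kg in this assay, at which 1 of the 2 values shown sits). Going by the values given here, the only measured step, a step that the two limits leave unreadable from compound 1 to compound 2, therefore cannot be read: two limits do not show how far apart the two compounds really lie.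

Compound 3, `CCOc1cccc(N/N=C2\CCC(C)n3c2ncc(C(=O)O)c3=O)c1`, differs from compound 1 in one place: ethoxy in place of bromo on an aromatic carbon. Among the compounds with values here, no measured step shows what exchanging bromo for ethoxy on this aromatic carbon does, and the step from compound 1 to compound 2 gives no usable size either. Both measured compounds sit at limits, so the most that can be expected is that compound 3 stays in the same region; the expected step is a number no higher from compound 1 to compound 3 (the limit leaves the size open), with no direction that the data could support beyond the scatter. Compound 3 is therefore estimated at 320 umol/kg, with a range from 100 umol/kg to 1000 umol/kg, and it is likely that this assay will again report only a limit.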

Compound 3, dose for 50% inhibition: > 1000 umol/kg
Compound 3 was reported as a limit (the forecaster's own chance of this, stated with the estimate: 70%); at least 3.1-fold (0.49 log units) between middle value and limit.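

Compound 3, like compound 1, is reported in this assay only as a limit and not as a number, so the step between these two compounds cannot be read. The compounds shown leave open what dose any of them would need for the effect, and what ethoxy in place of bromo changes.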